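This account rests on a few compounds, and the source may have more. Where it says the series, first, only, none or still open, it means among the compounds named here.

Compound 1 `C=CC(C)(O)CC[C@@H]1C(=C)CC[C@H](Br)[C@@]1(C)CCC(O)C(C)(C)O` gives > 100000 nM
Compound 2 `C=CC(C)(O)CC[C@@H]1C(=C)CC[C@H](Br)[C@@]1(C)CCC1OC1(C)C` gives 53800 nM
Compound 3 `C=CC(C)(O)CC[C@@H]1C(=C)CC[C@H](Br)[C@@]1(C)CCC(=O)C(C)C` gives > 100000 nM

These three compounds share one core, differ in one group and were all tested in a functional assay on HepG2 cells (Homo sapiens) for cytotoxicity, read by MTT assay, with a stated time of 48 h; on this read-out lower numbers stand for stronger inhibition and higher numbers for weaker inhibition. Compound 3 stands at a limit of the assay, > 100000 nM, and has no exact number. Compound 1 also stands at a limit, > 100000 nM. The picture so far is dominated by the limit of > 100000 nM in this assay, at which 2 of the 3 values shown sit. Only compound 2 has an exact number, 53800 nM.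

The next compound is compound 4 `C=CC(C)(O)CC[C@@H]1C(=C)CC[C@H](Br)[C@@]1(C)CCC(O)C(=C)C`, which has the same atoms as compound 3, joined differently: 1-hydroxy-2-methylprop-2-en-1-yl in place of isopropylcarbonyl on a saturated chain carbon, two bonds along the chain from a saturated ring carbon. In compound 4, 1-hydroxy-2-methylprop-2-en-1-yl takes the place of isopropylcarbonyl, on a saturated chain carbon, two bonds along the chain from a saturated ring carbon.

Three measured steps involve changes at this same place: an at least 1.8-fold lower number from compound 1 to compound 2 (0.26 log units; that floor lies within the scatter), an at least 1.8-fold higher number from compound 2 to compound 3 (0.26 log units; that floor lies within the scatter) and a step that the two limits leave unreadable from compound 1 to compound 3. None of them shows a readable size beyond the scatter, so no step beyond the scatter is expected in this assay. The expected step is a number no higher from compound 3 to compound 4 (the limit leaves the size open). A result reported only as a limit is also quite likely. The estimate for compound 4 is 100000 nM, with an expected range of 50000 nM to 200000 nM.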

Compound 4, half-maximal inhibitory concentration: > 100000 nM
Compound 4: no number, only a limit; the forecaster's own chance of this, stated with the estimate: 65%; the middle value lies on the limit itself.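

In this assay, putting 1-hydroxy-2-methylprop-2-en-1-yl in place of isopropylcarbonyl keeps the same atoms and brings in a hydrogen-bond donor, but it still gives no exact number: the steps from compound 3 and from compound 1 to compound 4 cannot be read, as each joins two limits. Against the only exact number in the set, the result reads as an at least 1.8-fold higher number from compound 2 to compound 4 (0.26 log units; that floor lies within the scatter), so even this comparison does not clearly separate the two compounds. Among the groups at this place, only 3,3-dimethyloxiran-2-yl in compound 2 gives an exact number, while the open-chain groups, with or without a hydrogen-bond donor, all end at the same mark: the limit of > 100000 nM in this assay, at which 3 of the 4 values shown sit.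

The compounds shown leave open whether compound 1, compound 3 and compound 4 differ from one another at all, and whether the edge of compound 2 over them is larger than the usual scatter. They also leave open what an amine, a carboxylic acid or a longer chain on this saturated chain carbon would give in this assay.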